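Ethoxy for dimethylamino on the aryl of compound 2

A few compounds are considered here, and "the series" means these few. Any claim that something is new, unique, unknown or untested is made for them only; others in the source may bear on it.

Among the compounds with values here, the two compounds measured so far share one core and differ in the aryl substituent and in the groups on the core. Compound 1 `CCCn1c(=O)c2nc(-c3ccc(S(=O)(=O)NCCCC(=O)OCC)cc3)[nH]c2n(CCC)c1=O` gives 0.24 nM in an assay for binding affinity to adenosine receptor A1 (Bos taurus); a lower number here means a stronger inhibitor, a higher number a weaker inhibitor. Compound 2 `CN(C)c1ccc(-c2nc3c(=O)n(C)c(=O)n(C)c3[nH]2)cc1` gives 1.8 nM in this assay, the higher of the two numbers; its nearest neighbour is compound 1, and the gap between them lies beyond the scatter. Within the data shown here, no pair of measured compounds differs in one place only, so no single measured step is available.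

Compound 3 `CCOc1ccc(-c2nc3c(=O)n(C)c(=O)n(C)c3[nH]2)cc1` is not yet measured. The change is ethoxy in place of dimethylamino on an aromatic carbon. Both groups carry one hydrogen-bond acceptor and no donor, and both are of three heavy atoms. Among the measured compounds shown here, with no measured step to lean on, the expected step from compound 2 to compound 3 is a 1.9-fold higher number from compound 2 to compound 3 (0.29 log units; within the scatter), a small weakening that need not reach beyond the scatter. For compound 3 the estimate in this assay is 3.5 nM, within a range from 0.9 nM to 14 nM.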

Compound 3, half-maximal inhibitory concentration: 2 nM
Beside the measured number, compound 3's estimate is 1.8-fold (0.24 log units) above it, and the stated range covers the measured number.
By their numbers in this assay, from the lowest: compound 1; then compounds 2 and 3 (each within the scatter of the next).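

At the aromatic carbon para to a large group, on the shared core of compound 2 and compound 3, ethoxy in place of dimethylamino gives a 1.1-fold higher number from compound 2 to compound 3 (0.05 log units; within the scatter) in this assay. Within the data shown here, this is the first step that can be read at a single place, and it shows that this exchange, between two groups that match in heavy atoms, hydrogen-bond donors and hydrogen-bond acceptors, leaves the number within the scatter, so this assay does not separate the two groups at this position. No measurement of any property of either group bears on this result, and the step carries no explanation.

Still open, going by these compounds, is how far this tolerance extends, since both groups are of one size and neither carries a hydrogen-bond donor: a primary amine, a hydroxyl, a carboxylic acid or a longer chain such as butoxy at the same carbon could behave differently. Also open, on these data alone, is whether the same exchange would hold on the core of compound 1 with its propyl groups, as compound 1 differs from compound 2 and compound 3 in more than one place and its gap to them cannot be assigned to any single group.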